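The source may report more compounds than this note shows. Statements on the series, on what has been measured and on what is new or still open speak of the compounds shown alone.

Compound 2 `COc1ccc(/C=N/NC(=O)Nc2ccc(Oc3ccnc(-c4nncn4CCN(C)C)c3)c(F)c2)c(OC)c1OC` gives the highest of the two numbers measured in a functional assay on NCI-H460 cells (Homo sapiens) for cytotoxicity, read by MTT assay, with a stated time of 72 h (on this read-out lower numbers stand for stronger inhibition and higher numbers for weaker inhibition), at 1790 nM. For the measured compounds named here, its nearest neighbour is compound 1 `CN(C)CCn1cnnc1-c1cc(Oc2ccc(NC(=O)N/N=C/c3ccc(O)c(Br)c3)cc2F)ccn1`, which in this assay gives 430 nM; the one measured step, a 4.2-fold higher number from compound 1 to compound 2 (0.62 log units; beyond the scatter), swaps the aryl group on the carbon with a double bond to nitrogen. Compound 3 `CN(C)CCn1cnnc1-c1cc(Oc2ccc(NC(=O)N/N=C/c3c(Cl)cccc3Cl)cc2F)ccn1` has not yet been measured in this assay. It differs from compound 2 in the same place: 2,6-dichlorophenyl in place of 2,3,4-trimethoxyphenyl on a carbon with a double bond to nitrogen. Going by the values given here, no measured pair exchanges 2,6-dichlorophenyl for any other group, so the only guide is that step from compound 1 to compound 2, which shows that this aryl group moves the number by a modest amount, and that a halogenated aryl gave the lower number. Compound 3 is therefore expected to fall between the two measured values, with a change of a 2.2-fold lower number from compound 2 to compound 3 (0.35 log units; beyond the scatter). The estimate for compound 3 in this assay is 800 nM, within a range of 250 nM to 2500 nM.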

Compound 3, half-maximal inhibitory concentration: 350 nM
Beside the measured number, compound 3's estimate is 2.3-fold (0.36 log units) above it, within the range that was stated.
By their numbers in this assay, from the lowest: compounds 3 and 1 (each within the scatter of the next); then compound 2.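

In this assay the exchange of 2,3,4-trimethoxyphenyl for 2,6-dichlorophenyl gives a 5.1-fold lower number from compound 2 to compound 3 (0.71 log units; beyond the scatter) and so shows that this position can move the number further than the first step alone indicated. The exchange of 3-bromo-4-hydroxyphenyl for 2,6-dichlorophenyl gives a 1.2-fold lower number from compound 1 to compound 3 (0.09 log units; within the scatter) and so shows that an aryl group without a hydroxyl can match compound 1 here, leaving compound 2 apart from the two halogenated aryl compounds. No measurement shown explains these differences.

For the compounds shown here, both methoxy loss and chlorine gain occur in the one step from compound 2 to compound 3, so their contributions cannot be separated. As far as these compounds go, whether an unsubstituted phenyl, or a phenyl carrying a single chlorine, an amine or a carboxylic acid, would align with compound 3 or compound 2 remains open.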